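Carboxymethoxy to (difluoromethyl)sulfanyl on a quinolinone-derived tertiary amine

The source may hold more compounds than are shown below. What is called first, only, known or untested is meant among the compounds shown, and "the series" means these compounds.

Measured compounds:
compound 1, `Cc1ccc2[nH]c(=O)c(CN(Cc3ccc(OCC(=O)O)cc3)Cc3ccc(C(C)(C)C)cc3)cc2c1`, > 10000 nM in a toxicity assay on MDCK cells (Canis lupus familiaris) for cytotoxicity, read by crystal violet staining, with a stated time of 48 h; a higher number here means that more compound is tolerated, a lower number that less compound is tolerated
compound 2, `CCc1ccc2[nH]c(=O)c(CN(Cc3ccc(OC(F)F)cc3)Cc3ccc(C(C)(C)C)cc3)cc2c1`, > 5000 nM in this assay

Compound 1 is known in this assay only as a limit of the assay and not as a number: compound 1 gives > 10000 nM, which is the limit of > 10000 nM in this assay, at which 1 of the 2 values shown sits. Compound 2 likewise sits at a limit in this assay, where compound 2 gives > 5000 nM. Among the measured compounds shown here, both values shown are therefore limits, and no measured step exists between them.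

Compound 3, `Cc1ccc2[nH]c(=O)c(CN(Cc3ccc(SC(F)F)cc3)Cc3ccc(C(C)(C)C)cc3)cc2c1`, differs from compound 1 in one place: (difluoromethyl)sulfanyl in place of carboxymethoxy on an aromatic carbon. For the measured compounds named here, no measured step covers this change. The expectation in this assay rests on compound 1 alone, and a step no larger than the usual scatter is expected, in either direction. The step from compound 1 to compound 3 is estimated as a number no higher from compound 1 to compound 3 (the limit leaves the size open). Compound 3 is expected to give 10000 nM in this assay, within 3000 nM to 30000 nM, most likely again reported only as a limit.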

Compound 3, half-maximal cytotoxic concentration: > 5000 nM
Compound 3 ended at the assay's limit; the forecaster's own chance of this, stated with the estimate: 60%; the middle value is on the limit's open side.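

Compound 1 and compound 3 are both known in this assay only as limits of the assay, so the step between them cannot be read. The compounds shown leave open what concentration any of them actually reaches, and whether replacing carboxymethoxy with (difluoromethyl)sulfanyl changes tolerance at all.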